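Removing a Methoxy Group from Compound 3

A few compounds are considered here, and "the series" means these few. Any claim that something is new, unique, unknown or untested is made for them only; others in the source may bear on it.

Compound 1 `CCC(c1ccc(-c2cscc2C)cc1)n1ccnc1` gives 27% in an assay for inhibition of steroid 17-alpha-hydroxylase/17,20 lyase (Homo sapiens), using NADPH, tested at 0.2 uM (a lower number here means a weaker effect, a higher number a stronger effect of the compound at the concentration tested), while compound 2 `Cc1cscc1-c1ccc(Cn2ccnc2)cc1` gives 0%, the shift being a number 27 percentage points lower from compound 1 to compound 2 (beyond the scatter). Compound 3 `COc1ccc(-c2csc(Cn3ccnc3)c2)cc1OC` gives 0% in this assay, level with compound 2 and together the lowest of the three numbers, with compound 1 the furthest away. Compound 4 `COc1ccc(-c2csc(Cn3ccnc3)c2)cc1` differs from compound 3 by hydrogen in place of methoxy on an aromatic carbon. Going by the values given here, no measured step involves a methoxy group; the only step known concerns an ethyl group on a saturated chain carbon, and compound 3 already sits at the lowest number seen. Compound 4 is therefore expected to show no change beyond the scatter, a number 4 percentage points higher from compound 3 to compound 4 (within the scatter). The estimate for compound 4 in this assay is 4%, within 0% to 18%.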

Compound 4, a percentage reported as inhibition, at one concentration (the size of the read-out at that concentration, not a potency): 0%
Compound 4: middle estimate off by 4 percentage points, on the high side, and the stated range covers the measured number.
By their numbers in this assay, from the lowest: compounds 2, 3 and 4 (each within the scatter of the next); then compound 1.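

Taking one methoxy group off the six-membered aromatic ring, at the place ortho to a methoxy group, gives no change at the digits printed from compound 3 to compound 4 (within the scatter) in this assay. Going by these compounds alone, this is the first reading of any change at this position, and compound 4 gives 0%, so with one methoxy group gone the number does not leave the lowest level seen. Starting from that level, the step could not show a further loss, and nothing measured bears on the result. As far as these compounds go, whether an amine or a hydroxyl group at this place would lift the number stays open, as does whether adding the ethyl group of compound 1 to the chain carbon of compound 4 would do so.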